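Indole ketones with a pyridylmethyl arm: phenyl to methoxy

A few compounds are considered here, and "the series" means these few. Any claim that something is new, unique, unknown or untested is made for them only; others in the source may bear on it.

Among the compounds with values here, compound 1 `O=C(Cc1cccnc1)c1cc2cc(-c3ccccc3)ccc2[nH]1` is the only member of the series with a numerical result so far: in an assay on isolated protein for inhibition of Indoleamine 2,3-dioxygenase 1 (Homo sapiens), read by spectrophotometry (a higher number here means a weaker inhibitor, a lower number a stronger inhibitor), compound 1 gives 96000 nM, a weak inhibitor. Compound 2 `COc1ccc2[nH]c(C(=O)Cc3cccnc3)cc2c1OCc1ccccc1` is recorded in this assay as "not active" (no number reported). Compound 3 `OC(Cc1cccnc1)c1cc2ccccc2[nH]1` is likewise recorded in this assay as "not active" (no number reported). Within the data shown here, no step between two numbered values is available, so compound 1 serves as the sole anchor.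

Compound 4 `COc1ccc2[nH]c(C(=O)Cc3cccnc3)cc2c1` differs from compound 1 by methoxy in place of phenyl on an aromatic carbon. Compound 2, which also carries methoxy on the core and gives "not active" (no number reported), suggests that the change does not help. The step is expected to be a 2.3-fold higher number from compound 1 to compound 4 (0.36 log units; beyond the scatter), toward weaker inhibition, and beyond the scatter. Compound 4 is therefore estimated at 220000 nM, with a range of 70000 nM to 700000 nM, with a real chance that no number is obtained.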

Compound 4, half-maximal inhibitory concentration: 49000 nM
Estimate against measurement, compound 4: 4.5-fold (0.65 log units) above; the measured number lies below the stated range.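

In this assay, methoxy in place of phenyl on an aromatic carbon gives a 2.0-fold lower number from compound 1 to compound 4 (0.29 log units; within the scatter), so this position accepts the loss of the six-membered aromatic ring with no change that can be read. Methoxy on the core therefore does not by itself account for the "not active" record of compound 2. Nothing available bears on why compound 1 and compound 4 read alike. From the compounds shown here alone, whether an amine, a carboxylic acid or a longer chain at this position would give a step beyond the scatter remains open.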